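Two lactam isomers at the cytotoxicity limit

This account rests on a few compounds, and the source may have more. Where it says the series, first, only, none or still open, it means among the compounds named here.

In a functional assay on XF498 cells (Homo sapiens) for cytotoxicity (a higher number here means that more compound is needed for the effect, a lower number that less compound is needed), compound 2 (`CC1=C(O)[C@@H](C/C(C)=C\CC[C@H](C)/C=C/C=C(\C)CCCC2=CCN(CC(=O)O)C2=O)OC1=O`) gives > 30 ug/mL, a limit of the assay and not a number. Compound 1 (`COC1C=C(CCC/C(C)=C/C=C/[C@@H](C)CC/C=C(/C)C[C@H]2OC(=O)C(C)=C2O)C(=O)O1`) gives > 30 ug/mL, likewise a limit. For the measured compounds named here, the series so far therefore stands at one point: the limit of > 30 ug/mL in this assay, at which 2 of the 2 values shown sit. Compound 2 has no numerical value from which to measure a change.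

Compound 3 (`CC1=C(O)[C@@H](C/C(C)=C\CC[C@H](C)/C=C/C=C(\C)CCCC2=CC(=O)N(CC(=O)O)C2)OC1=O`) has the same atoms as compound 2, joined differently: a group of 10 heavy atoms (6 carbon, 1 nitrogen, 3 oxygen; one five-membered non-aromatic ring with 1 hetero atom) in place of a group of 10 heavy atoms (6 carbon, 1 nitrogen, 3 oxygen; one five-membered non-aromatic ring with 1 hetero atom), on a saturated chain carbon, three bonds along the chain from a double-bonded chain carbon. The change is confined to the ring-bearing group, and the rest of the structure stays the same.

Going by the values given here, only one measured step bears on this change, and it does so indirectly, as it replaces the same part of the structure: a step that the two limits leave unreadable from compound 1 to compound 2. Among the compounds with values here, it gives no size to carry over to the isomer pair, and no measured step describes a rearrangement of this kind. Because of the limit of > 30 ug/mL in this assay, at which 2 of the 2 values shown sit, the expected step, a step that the limit leaves unreadable from compound 2 to compound 3, is none beyond the scatter, with no direction favoured. A further limit is the most likely report.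

For compound 3 the estimated value is 35 ug/mL, with an expected range from 14 ug/mL to 70 ug/mL.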

Compound 3, concentration for half-maximal effect: > 30 ug/mL
Compound 3 was reported as a limit; the forecaster's own chance of this, stated with the estimate: 75%; the middle value is on the limit's open side.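

In this assay compound 3 gives > 30 ug/mL, a limit of the assay and not a number. No step among compound 1, compound 2 and compound 3 can be read, because all three stand at that limit: the limit of > 30 ug/mL in this assay, at which 3 of the 3 values shown sit.

The compounds shown leave open how these three rank in this assay, and whether any change in the ring-bearing group gives a numerical value.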